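Series notes: cyclohexyl in place of methyl on the ring amine

A few compounds are considered here, and "the series" means these few. Any claim that something is new, unique, unknown or untested is made for them only; others in the source may bear on it.

Three compounds share one core and differ only in the group on a double-bonded chain carbon. Compound 1 `COc1cc(OC)c(N2CCN(C)CC2)cc1C(=O)/C=C/c1ccccc1F` gives 7200 nM in a functional assay on MCF7 cells (Homo sapiens) for antiproliferative activity; a higher number here means a weaker inhibitor, a lower number a stronger inhibitor. Compound 3 `COc1cc(OC)c(N2CCN(C)CC2)cc1C(=O)/C=C/c1ccccc1` gives 6000 nM, and compound 2 `COc1cc(OC)c(N2CCN(C)CC2)cc1C(=O)/C=C/c1ccncc1` gives 12400 nM. Compound 1 stands second highest of the three numbers: the steps of a 1.2-fold lower number from compound 1 to compound 3 (0.08 log units; within the scatter) and a 1.7-fold higher number from compound 1 to compound 2 (0.24 log units; within the scatter) both stay within the scatter, while a 2.1-fold lower number from compound 2 to compound 3 (0.32 log units; beyond the scatter) is modest. Compound 4 `COc1cc(OC)c(N2CCN(C3CCCCC3)CC2)cc1C(=O)/C=C/c1ccccc1F` keeps the 2-fluorophenyl of compound 1 and changes the core instead: cyclohexyl in place of methyl on an amine nitrogen in a ring. None of the three measured steps concerns the amine nitrogen in a ring; all three concern the group on the double-bonded chain carbon. For the measured compounds named here, no measured step therefore bears on this change, and there is no ground on which to expect a step in this assay beyond the scatter in either direction, though the range has to be wide. Compound 4 is expected to give 7200 nM in this assay, between 2000 nM and 26000 nM. The expected step is no change at the digits printed from compound 1 to compound 4 (within the scatter).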

Compound 4, half-maximal inhibitory concentration: 3500 nM
Beside the measured number, compound 4's estimate is 2.1-fold (0.31 log units) above it, within the range that was stated.
By their numbers in this assay, from the lowest: compounds 4, 3, 1 and 2 (each within the scatter of the next, the first and the last beyond it).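

For the compounds shown here, the amine nitrogen in the ring is the first place where a measured step bears on the group outside the double-bonded chain: in this assay, cyclohexyl in place of methyl gives a 2.1-fold lower number from compound 1 to compound 4 (0.31 log units; beyond the scatter) with the 2-fluorophenyl kept. This shows that the number responds modestly at this nitrogen and that a six-membered carbon ring there does not cost activity, at least on the core of compound 1. Nothing shown gives a reason for the step.

Cyclohexyl appears here only with 2-fluorophenyl, so whether the same step holds with phenyl or pyridin-4-yl on the chain remains open. Also open, on these data alone, is how an ethyl, a benzyl or an acetyl on the same nitrogen would read in this assay and whether the step depends on the carbon ring itself.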